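A few compounds are considered here, and "the series" means these few. Any claim that something is new, unique, unknown or untested is made for them only; others in the source may bear on it.

Compound 1 `O=C(NC(=S)Nc1ccc(F)cc1)c1cn(-c2ccccc2)nc1-c1ccc(F)cc1`: 3240 nM
Compound 2 `Cc1ccc(NC(=S)NC(=O)c2cn(-c3ccccc3)nc2-c2ccccc2)cc1`: 3960 nM
Compound 3 `O=C(NC(=S)Nc1ccc(F)cc1)c1cn(-c2ccccc2)nc1-c1ccccc1`: 4210 nM

These three compounds were tested in a functional assay on NCI-H460 cells (Homo sapiens) for inhibition, read by CCK-8 assay, with a stated time of 48 h; a higher number here means a weaker inhibitor, a lower number a stronger inhibitor. Among the measured compounds shown here, on the numbers so far, compound 2 carries the second highest number of the three, but its gaps to the others are within the scatter: the step of a 1.1-fold higher number from compound 2 to compound 3 (0.03 log units; within the scatter), and compound 1 sits only a little lower than compound 2 . In effect the three cannot be told apart in this assay .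

Compound 4 `COc1ccc(-c2nn(-c3ccccc3)cc2C(=O)NC(=S)Nc2ccc(C)cc2)cc1` differs from compound 2 in one place: methoxy in place of hydrogen on an aromatic carbon. The phenyl on the shared core thus becomes 4-methoxyphenyl. The step that bears most directly on this is a 1.3-fold higher number from compound 1 to compound 3 (0.11 log units; within the scatter), which altered the same ring and moved the number by less than the scatter. The step of a 1.1-fold higher number from compound 2 to compound 3 (0.03 log units; within the scatter), on the other ring, was likewise flat. Nothing measured here shows this ring to matter; the expectation is a step within the scatter in this assay from compound 2 to compound 4 .

Compound 4 is therefore expected to give 3600 nM, within a range of 1500 nM to 8500 nM. This estimate means the step of a 1.1-fold lower number from compound 2 to compound 4 (0.04 log units; within the scatter), which is expected to stay within the scatter.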

Compound 4, half-maximal inhibitory concentration: 2880 nM
Beside the measured number, compound 4's estimate is 1.3-fold (0.10 log units) above it, within the range that was stated.
By their numbers in this assay, from the lowest: compounds 4, 1, 2 and 3 (each within the scatter of the next).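

In this assay, replacing hydrogen with methoxy para to a large group gives a 1.4-fold lower number from compound 2 to compound 4 (0.14 log units; within the scatter). The earlier step at this position, a 1.3-fold higher number from compound 1 to compound 3 (0.11 log units; within the scatter), involved only fluoro, so compound 4 adds something new: a group of 2 heavy atoms with a hydrogen-bond acceptor also produces no step beyond the scatter on this ring. Nothing measured here offers an explanation for the size of this step.

As far as these compounds go, it remains open whether an amine, a carboxylic acid or a longer chain at this position would move the number beyond the scatter. Also open, from the compounds shown here alone, is whether methoxy would give a similar step with fluoro, rather than methyl, on the other aromatic ring.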